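This account rests on a few compounds, and the source may have more. Where it says the series, first, only, none or still open, it means among the compounds named here.

Of the compounds shown here, two have been measured in a functional assay on microsomes for inhibition, with a stated time of 1 h; on this read-out lower numbers stand for stronger inhibition and higher numbers for weaker inhibition. Compound 1 `CSc1nc(-c2cccs2)c(C#N)c(=O)n1C` gives 83 ug/mL in this assay. Compound 2 `COc1cccc(-c2nc(SC)n(C)c(=O)c2C#N)c1OC` gives 48 ug/mL in this assay, and the two readings cannot be told apart within the usual scatter of the measurement. Among the measured compounds shown here, no pair of measured compounds differs in a single place, so the account rests on these two values alone.

Compound 3 `Cn1c(NN)nc(-c2cccs2)c(C#N)c1=O` has not yet been measured. It differs from compound 1 in one place: aminoamino in place of methylsulfanyl on an aromatic carbon. For the measured compounds named here, nothing among the measured compounds shows how such an exchange acts in this assay, so the expected step is taken to be small, with no direction favoured and most likely none beyond the scatter, as expressed by a 1.2-fold lower number from compound 1 to compound 3 (0.07 log units; within the scatter). On that basis compound 3 is estimated at 70 ug/mL in this assay, with a range from 25 ug/mL to 200 ug/mL.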

Compound 3, half-maximal inhibitory concentration: 68 ug/mL
Estimate against measurement, compound 3: 1.0-fold (0.01 log units) above; the range from low to high includes it.
By their numbers in this assay, from the lowest: compounds 2, 3 and 1 (each within the scatter of the next).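

This position, on an aromatic carbon between two ring nitrogen atoms, now has a step that can be read: in this assay, aminoamino in place of methylsulfanyl gives a change that lies within the scatter (a 1.2-fold lower number from compound 1 to compound 3 (0.09 log units; within the scatter)). The position thus accepts this exchange without a shift that can be told from the usual variation, even though the two groups differ in their atoms and in their hydrogen-bond donors. Nothing measured here bears on the reason for this result.

Going by these compounds, whether a plain amine, a carboxylic acid or a longer chain at this position would move the reading beyond the scatter remains open. On these data alone, it also remains open whether aminoamino would behave in the same way on the core of compound 2.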